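The compounds below may be only part of what the source reports. "The series", "measured", "known", "first", "only" and "open" are said of these compounds alone.

Measured so far:
compound 1 `COc1cc(/C=C2\CN(C)C/C(=C\c3ccc(Br)cc3)C2=O)cc(OC)c1OC`: 12400 nM
compound 2 `COc1cc(/C=C2\CN(C)C/C(=C\c3ccc(Cl)c(Cl)c3)C2=O)cc(OC)c1OC`: 16200 nM

In a functional assay on K562 cells (Homo sapiens) for cytotoxicity, read by MTT assay, with a stated time of 24 h (on this read-out higher numbers stand for weaker inhibition and lower numbers for stronger inhibition), compound 1 gives 12400 nM and compound 2 gives 16200 nM. Among the measured compounds shown here, compound 2 holds the higher of the two numbers, yet the only step measured, a 1.3-fold higher number from compound 1 to compound 2 (0.12 log units; within the scatter), stays within the scatter, so compound 1 and compound 2 cannot be told apart on this read-out.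

The next compound is compound 3 `COc1cc(/C=C2\CN(C)C/C(=C\c3ccc(C#N)cc3)C2=O)cc(OC)c1OC`. The change from compound 2 is 4-cyanophenyl in place of 3,4-dichlorophenyl on a double-bonded chain carbon bound to a double-bonded ring carbon. For the measured compounds named here, the one step measured so far, a 1.3-fold higher number from compound 1 to compound 2 (0.12 log units; within the scatter), changed the group at the same place and produced no movement beyond the scatter. Going by the values given here, no measured step involves a 4-cyanophenyl group, so nothing points to a shift in either direction in this assay.

Compound 3 is therefore expected to give 14000 nM, within a range of 5000 nM to 40000 nM. This estimate means a 1.2-fold lower number from compound 2 to compound 3 (0.06 log units; within the scatter), a step expected to lie within the scatter.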

Compound 3, half-maximal inhibitory concentration: 4290 nM
Estimate against measurement, compound 3: 3.3-fold (0.51 log units) above; the whole stated range lies above it.
By their numbers in this assay, from the lowest: compound 3; then compounds 1 and 2 (each within the scatter of the next).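

Notes on the aryl group on a double-bonded chain carbon bound to a double-bonded ring carbon: in this assay this place is not indifferent to substitution, since 4-cyanophenyl gives a clear drop (a 3.8-fold lower number from compound 2 to compound 3 (0.58 log units; beyond the scatter)). The single replacement of cyano for bromo on an aromatic carbon gives a drop of similar order (a 2.9-fold lower number from compound 1 to compound 3 (0.46 log units; beyond the scatter)), so compound 3 stands lowest of the three, while 4-bromophenyl and 3,4-dichlorophenyl could not be separated (a 1.3-fold higher number from compound 1 to compound 2 (0.12 log units; within the scatter)). Nothing at hand accounts for the drop.

From the compounds shown here alone, with a single nitrile example, it remains open whether the lower number belongs to that group alone or would extend to other replacements of the halogens. A carboxylic acid, an amine or a longer chain on the same aromatic ring could move the number either way.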